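Swapping a propyl chain for a carbamate-bearing side chain

The source may hold more compounds than are shown below. What is called first, only, known or untested is meant among the compounds shown, and "the series" means these compounds.

Of the compounds shown here, two built on the same bis-aziridinyl quinone core have been measured in a functional assay on L1210 cells (Mus musculus), with a stated time of 1 days; a lower number here means a less potent compound, a higher number a more potent compound, by a factor of ten per unit of this negative logarithm. Compound 1, `CCCC1=C(N2CC2)C(=O)C(CCC)=C(N2CC2)C1=O`, gives 4.32, the lower of the two numbers. Compound 2, `CC1=C(N2CC2)C(=O)C(C(C)COC(N)=O)=C(N2CC2)C1=O`, gives 5.93, a number well beyond the usual scatter above compound 1. The step from compound 1 to compound 3, `CCCC1=C(N2CC2)C(=O)C(C(COC(N)=O)OC)=C(N2CC2)C1=O`, replaces the propyl group with a larger, more polar-looking chain: a group of 8 heavy atoms (4 carbon, 1 nitrogen, 3 oxygen; no ring) in place of a group of 3 heavy atoms (3 carbon; no ring), on a double-bonded ring carbon. Among the measured compounds shown here, no measured pair in this set differs in exactly this way, so the expectation rests on compound 2, whose side chain resembles the entering group and which gives 5.93. A clear upward step is therefore expected, of a size similar to the gap between compound 1 and compound 2. Compound 3 is expected to give about 5.8, within a range from 5 to 6.6. The expected rise is a number 1.48 log units higher from compound 1 to compound 3 (beyond the scatter).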

Compound 3, logarithm of the reciprocal of the active concentration, log(1/C): 5.01
Beside the measured number, compound 3's estimate is 0.79 log units above it; the measured number falls inside the stated range.
By their numbers in this assay, from the lowest: compound 1; then compound 3; then compound 2.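

In this assay, among the compounds shown here, replacing one propyl group of compound 1 with the group of 8 heavy atoms gives a number 0.69 log units higher from compound 1 to compound 3 (beyond the scatter) and provides the first direct reading at this position. The rise shows that this double-bonded ring carbon need not carry a small all-carbon chain: a larger group with a hydrogen-bond donor and hydrogen-bond acceptors is accepted, and potency increases while the rest of the molecule stays the same. Nothing measured here explains why the number rises.

A single step cannot show whether the gain comes from the whole entering group or only from part of it, such as the carbamate end. It also leaves open how a simpler group, such as a hydroxymethyl group or a primary amine on a short chain, would compare with propyl at this position.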